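Aryl exchange at the saturated ring carbon: cytotoxicity notes

The source may hold more compounds than are shown below. What is called first, only, known or untested is meant among the compounds shown, and "the series" means these compounds.

Working notes on a series sharing one core, in which a substituted phenyl group sits on a saturated ring carbon of a five-membered non-aromatic ring. Compound 1 `CNC(=O)c1cc(Oc2ccc(C3=NNC(c4ccc(C#N)cc4)C3)cc2)ccn1` carries 4-cyanophenyl there; in a functional assay on HepG2 cells (Homo sapiens) for cytotoxicity, read by MTT assay, with a stated time of 72 h (on this read-out lower numbers stand for stronger inhibition and higher numbers for weaker inhibition), compound 1 gives 15000 nM. Compound 2 `CNC(=O)c1cc(Oc2ccc(C3=NNC(c4ccc(F)cc4Cl)C3)cc2)ccn1` carries 2-chloro-4-fluorophenyl, and in this assay compound 2 gives 11500 nM. Compound 3 `CNC(=O)c1cc(Oc2ccc(C3=NNC(c4ccc(OC)cc4)C3)cc2)ccn1` carries 4-methoxyphenyl, and in this assay compound 3 gives 9640 nM. On the numbers shown compound 1 has the highest number of the three, yet a 1.3-fold lower number from compound 1 to compound 2 (0.12 log units; within the scatter) and a 1.6-fold lower number from compound 1 to compound 3 (0.19 log units; within the scatter) both stay within the scatter, as does a 1.2-fold lower number from compound 2 to compound 3 (0.08 log units; within the scatter).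

Compound 4 `CNC(=O)c1cc(Oc2ccc(C3=NNC(c4cccc(Cl)c4Cl)C3)cc2)ccn1` has not yet been measured. Its change from compound 1 is 2,3-dichlorophenyl in place of 4-cyanophenyl on a saturated ring carbon. Among the compounds with values here, the steps that bear on it are a 1.3-fold lower number from compound 1 to compound 2 (0.12 log units; within the scatter) and a 1.6-fold lower number from compound 1 to compound 3 (0.19 log units; within the scatter), each an exchange of the phenyl group at the same saturated ring carbon, and neither moved beyond the scatter. No step beyond the scatter is therefore expected in this assay; for compound 4 the expected step is a 1.4-fold lower number from compound 1 to compound 4 (0.13 log units; within the scatter). The estimate for compound 4 in this assay is 11000 nM, with a range from 5000 nM to 25000 nM.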

Compound 4, half-maximal inhibitory concentration: 4990 nM
The estimate for compound 4 lay 2.2-fold (0.34 log units) above the measured number, outside the stated range (below it).
By their numbers in this assay, from the lowest: compounds 4, 3, 2 and 1 (each within the scatter of the next, the first and the last beyond it).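

Within the data shown here, at this saturated ring carbon, exchange of the phenyl group can move the number beyond the scatter in this assay: 2,3-dichlorophenyl gives a 3.0-fold lower number from compound 1 to compound 4 (0.48 log units; beyond the scatter) and a 2.3-fold lower number from compound 2 to compound 4 (0.36 log units; beyond the scatter), which no step among the earlier compounds did. The separation is not general, since the exchange of 4-methoxyphenyl for 2,3-dichlorophenyl gives a 1.9-fold lower number from compound 3 to compound 4 (0.29 log units; within the scatter), so 2,3-dichlorophenyl stands apart from 4-cyanophenyl and 2-chloro-4-fluorophenyl but not from 4-methoxyphenyl. No measurement at hand accounts for these steps.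

The compounds shown leave open whether both chlorines of 2,3-dichlorophenyl are needed for these steps, as a phenyl group with a single chlorine at either of those places would show. They also leave open how an amine or a carboxylic acid on this phenyl group would read in this assay.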